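The source may hold more compounds than are shown below. What is called first, only, known or untested is meant among the compounds shown, and "the series" means these compounds.

Compound 1 `COc1ccc(-n2nncc2CN2C(=O)C3(C(C#N)=C(N)Oc4c3c3nc5ccccc5nc3c3ccccc43)c3ccccc32)cc1` was tested in an ADME assay on HUVEC cells (Homo sapiens) for antiproliferative activity, read by MTT assay, with a stated time of 48 h; a higher number here means a weaker inhibitor, a lower number a stronger inhibitor. In this assay compound 1 reached only the limit of the assay, reported as > 50000 nM. Compound 2 `Cc1ccccc1-n1nncc1CN1C(=O)C2(C(C#N)=C(N)Oc3c(N)cc4nc5ccccc5nc4c32)c2ccccc21` was tested in the same way. In this assay compound 2 likewise reached only the limit, > 50000 nM. Where compound 2 stands is thus given by a limit rather than a number, and the other value shown is a limit as well (the limit of > 50000 nM in this assay, at which 2 of the 2 values shown sit). Compound 3 `Cc1cccc(-n2nncc2CN2C(=O)C3(C(C#N)=C(N)Oc4c(N)cc5nc6ccccc6nc5c43)c3ccccc32)c1` has not yet been measured. It differs from compound 2 by a single change (3-methylphenyl in place of 2-methylphenyl on an aromatic nitrogen), 3-methylphenyl in place of 2-methylphenyl on an aromatic nitrogen. Within the data shown here, no step between measured compounds exists for this kind of change. The step that the limit leaves unreadable from compound 2 to compound 3 is expected to stay within the scatter, with no direction to it. In this assay compound 3 is estimated at 60000 nM, in a range from 20000 nM to 200000 nM, with a limit the most likely outcome.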

Compound 3, half-maximal inhibitory concentration: > 50000 nM
Compound 3 was reported as a limit; the forecaster's own chance of this, stated with the estimate: 85%; the middle value is on the limit's open side.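

No step can be read from compound 2 to compound 3, since both results in this assay are limits and not numbers: the limit of > 50000 nM in this assay, at which 3 of the 3 values shown sit. The compounds shown leave open how 3-methylphenyl and 2-methylphenyl compare, and whether any of these compounds has a measurable value in this assay at all.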